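Trifluoromethoxy for methyl: the step to compound 4

A few compounds are considered here, and "the series" means these few. Any claim that something is new, unique, unknown or untested is made for them only; others in the source may bear on it.

Compound 1 (`Cc1ccc2nc(-c3ccccc3N(C)C)[nH]c(=O)c2c1`): 14000 nM
Compound 2 (`CCN(CC)c1ccc2nc(-c3ccccc3OC(F)(F)F)[nH]c(=O)c2c1`): 40 nM
Compound 3 (`Cc1ccc2nc(-c3ccccc3C)[nH]c(=O)c2c1`): 4580 nM

In a functional assay on HeLa cells (Homo sapiens) for cytotoxicity, read by MTT assay, with a stated time of 2 days (a lower number here means a stronger inhibitor, a higher number a weaker inhibitor), compound 3 gives 4580 nM as the second highest of the three numbers, with compound 1 above it and compound 2 far below it. Compound 4 (`Cc1ccc2nc(-c3ccccc3OC(F)(F)F)[nH]c(=O)c2c1`) has trifluoromethoxy in place of methyl on an aromatic carbon, ortho to a large group (trifluoromethoxy in place of methyl on an aromatic carbon). Among the compounds with values here, the one measured step at this group is a 3.1-fold lower number from compound 1 to compound 3 (0.49 log units; beyond the scatter) (methyl in place of dimethylamino), and it is modest. Compound 2 (40 nM) also carries trifluoromethoxy, but its core bears diethylamino where compound 3 and compound 4 bear methyl. The data do not separate those two differences, and only part of that gap can be expected to carry over. A modest move to a lower number is therefore expected in this assay, and the estimated change is a 2.5-fold lower number from compound 3 to compound 4 (0.41 log units; beyond the scatter) in this assay. The expected value for compound 4 is 1800 nM (estimated range 400 nM to 7000 nM).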

Compound 4, half-maximal inhibitory concentration: 850 nM
Beside the measured number, compound 4's estimate is 2.1-fold (0.33 log units) above it; low and high end bracket the measured number.
By their numbers in this assay, from the lowest: compound 2; then compound 4; then compound 3; then compound 1.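

In this assay the trifluoromethoxy change on an aromatic carbon ortho to a large group now stands alone with the core methyl unchanged, as a 5.4-fold lower number from compound 3 to compound 4 (0.73 log units; beyond the scatter) and a modest step. Compound 4 also isolates the other difference carried by compound 2, and a 21-fold higher number from compound 2 to compound 4 (1.33 log units; beyond the scatter) for methyl in place of diethylamino is a large step, so in this series the core group counts for more than the trifluoromethoxy change. Measured against dimethylamino, trifluoromethoxy gives a 16-fold lower number from compound 1 to compound 4 (1.22 log units; beyond the scatter) in the same setting, a large step where methyl gave only a modest one.

Nothing at hand explains these steps. The compounds shown leave open whether methoxy or chlorine on this aromatic carbon would match trifluoromethoxy, and whether a morpholine or a shorter amine on the core would keep the low number of compound 2.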